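The compounds below may be only part of what the source reports. "The series", "measured", "known", "first", "only" and "open" are said of these compounds alone.

Two measured compounds open this series. Compound 1, `CCCCC1([C@H](O)/C=C/C2CCC(=O)[C@@H]2C/C=C\CCCC(=O)O)CCC1`, is tested in a functional assay on the whole organism (strain Hartley) for inhibition, with Cavia porcellus as the target, with stated times of 15 min and 2 min (on this read-out lower numbers stand for an effect already at smaller amounts and higher numbers for an effect only at larger amounts of compound), and gives 0.00767 mg/kg. Compound 2, `CCCCC1([C@@H](O)/C=C/C2[C@H](O)CC(=O)[C@@H]2C/C=C\CCCC(=O)O)CCC1`, gives in this assay a value of 0.305 mg/kg. On those two numbers compound 2 stands at the higher end: its nearest neighbour is compound 1, whose number is lower by a margin well beyond the usual scatter of repeated measurements.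

The step to follow leads from compound 2 to compound 3, `CCCCC1([C@H](O)/C=C/C2[C@H](O)CC(=O)[C@@H]2C/C=C\CCCC(=O)O)CCC1`. The change is small on paper: the two compounds have the same atoms and bonds; at least one stereo element is drawn with a configuration in one of them and without one in the other: 1 of 6 stereo elements differ; a stereocentre at a saturated chain carbon is drawn S in compound 2 and R in compound 3. No other atom moves, so this is purely a question of how a single hydroxyl-bearing carbon in the side chain is drawn.

Going by the values given here, for the step itself there is no measured pair of the same kind to lean on, so what follows is an expectation rather than a rule. The guess here is that compound 3 moves toward the lower numbers rather than away from them, with the estimated step from compound 2 to compound 3 being a 15-fold lower number from compound 2 to compound 3 (1.18 log units; beyond the scatter). Put as a value, compound 3 is expected to give about 0.02 mg/kg in this assay, somewhere between 0.004 mg/kg and 0.1 mg/kg.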

Compound 3, dose for half-maximal effect: 0.00251 mg/kg
Estimate against measurement, compound 3: 8.0-fold (0.90 log units) above; measured number outside the range, below it.
By their numbers in this assay, from the lowest: compound 3; then compound 1; then compound 2.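

In this assay, the stereocentre at the saturated chain carbon matters far more than its small change on paper suggests: with no atom added or removed, the step from S to R gives a 120-fold lower number from compound 2 to compound 3 (2.08 log units; beyond the scatter), so the R drawing shows its effect at much smaller amounts of compound. The ring hydroxy can now also be read on its own, since hydroxy in place of hydrogen on a saturated ring carbon gives a 3.1-fold lower number from compound 1 to compound 3 (0.49 log units; beyond the scatter), a modest step but beyond the scatter, and with the chain carbon drawn R this added group does not push the number upward. One caution applies to how firmly the first of these steps can be tied to a single configuration: the fact that one of compounds 2 and 3 is drawn with a defined configuration and the other without, at the place where they differ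

From the compounds shown here alone, the ring hydroxy has been read only with the chain carbon drawn R, so it remains open whether its step would have the same direction and size with that carbon drawn S. Also open is how the number would respond if a methoxy group or a ketone took the place of the side-chain hydroxyl, or if an amide took the place of the carboxylic acid.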